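Hydrogen in place of benzoyl on compound 2

The compounds below may be only part of what the source reports. "The series", "measured", "known", "first", "only" and "open" are said of these compounds alone.

Compound 2 `O=C(OCCOCN1c2ccccc2C(=O)N(Cc2ccccc2)S1(=O)=O)c1ccccc1` gives 17 ug/mL in a functional assay on HEL cells (Homo sapiens) (a lower number here means that less compound is tolerated, a higher number that more compound is tolerated), the lowest of the two numbers measured. The nearest number is that of compound 3 `O=C1c2ccccc2NS(=O)(=O)N1COCc1ccccc1`, which gives 148 ug/mL in this assay, a gap beyond the usual scatter. Compound 1 `O=C1c2ccccc2NS(=O)(=O)N1Cc1ccccc1` gives only a limit, > 50 ug/mL, in this assay. One of the three values is thus (the limit of > 50 ug/mL in this assay, at which 1 of the 3 values shown sits).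

Compound 4 `O=C1c2ccccc2N(COCCO)S(=O)(=O)N1Cc1ccccc1` differs from compound 2 in one place: hydrogen in place of benzoyl on an oxygen on a saturated carbon. For the measured compounds named here, no step between two measured compounds isolates this change. Since compound 3 is more tolerated than compound 2, the change is expected to raise the number, with an estimated step of a 3.5-fold higher number from compound 2 to compound 4 (0.55 log units; beyond the scatter) in this assay. Compound 4 is therefore estimated at 60 ug/mL, with a range from 20 ug/mL to 200 ug/mL.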

Compound 4, half-maximal cytotoxic concentration: 125 ug/mL
Beside the measured number, compound 4's estimate is 2.1-fold (0.32 log units) below it; the measured number falls inside the stated range.
By their numbers in this assay, from the lowest: compound 2; then compounds 4 and 3 (each within the scatter of the next).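

For the compounds shown here, replacing benzoyl with hydrogen on this oxygen, which turns the 2-(benzoyloxy)ethyl end of the chain into 2-hydroxyethyl, gives the first readable step at this position in this assay (a 7.4-fold higher number from compound 2 to compound 4 (0.87 log units; beyond the scatter)). The low number of compound 2 therefore goes with the benzoyl group, not with the chain that carries it. The step from compound 1 cannot be read because compound 1 gives only a limit: the limit of > 50 ug/mL in this assay, at which 1 of the 4 values shown sits.

From the compounds shown here alone, whether a smaller acetyl group or a methyl ether on this oxygen would stay close to compound 4 or fall towards compound 2 remains open.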